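Trimming a chloro from the aniline of compound 3

The source may report more compounds than this note shows. Statements on the series, on what has been measured and on what is new or still open speak of the compounds shown alone.

Compound 1 `CN1CCN(CCCOc2cccc3nc(Nc4ccc(Cl)c(F)c4)ccc23)CC1` — 2390 nM
Compound 2 `CC(C)c1ccc(Nc2ccc3c(OCCCN4CCN(C)CC4)cccc3n2)cc1` — 16400 nM
Compound 3 `CN1CCN(CCCOc2cccc3nc(Nc4cc(Cl)cc(Cl)c4)ccc23)CC1` — 1780 nM

Three compounds share one core and differ only in the aromatic group attached to the nitrogen. In a functional assay on A498 cells (Homo sapiens) for inhibition, read by sulforhodamine B assay, with a stated time of 48 h (a higher number here means a weaker inhibitor of growth, a lower number a stronger inhibitor of growth), compound 3 has the lowest number of the three, but its gap to compound 1 is small: a 1.3-fold lower number from compound 1 to compound 3 (0.13 log units; within the scatter). Compound 2 stands apart, with a 6.9-fold higher number from compound 1 to compound 2 (0.84 log units; beyond the scatter) and a 9.2-fold lower number from compound 2 to compound 3 (0.96 log units; beyond the scatter), so the two halogenated phenyl groups behave alike while the isopropylphenyl group gives a clearly weaker compound.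

Compound 4 `CN1CCN(CCCOc2cccc3nc(Nc4cccc(Cl)c4)ccc23)CC1` has not been measured. It differs from compound 3 by hydrogen in place of chloro on an aromatic carbon. Going by the values given here, the one measured step that bears most directly on this change is the swap between two halogenated phenyl groups, a 1.3-fold lower number from compound 1 to compound 3 (0.13 log units; within the scatter), which stayed within the scatter. The larger steps involving compound 2 concern a non-halogen group and speak less to this case. Removing a chloro while keeping a chloro on the same ring is therefore expected to move the number little, perhaps slightly upward, and the expected step is a 1.5-fold higher number from compound 3 to compound 4 (0.16 log units; within the scatter). In this assay compound 4 is estimated at 2600 nM, with a likely range from 1000 nM to 6500 nM.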

Compound 4, concentration for 50% growth inhibition: 1880 nM
The estimate for compound 4 lay 1.4-fold (0.14 log units) above the measured number; measured number inside the range.
By their numbers in this assay, from the lowest: compounds 3, 4 and 1 (each within the scatter of the next); then compound 2.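

In this assay, the second chloro of the 3,5-dichlorophenyl group can be replaced by hydrogen with no readable effect (a 1.1-fold higher number from compound 3 to compound 4 (0.02 log units; within the scatter)), so the 3-chlorophenyl group serves as well as the ring with two chloro groups. The earlier compounds shown here compared only whole aromatic groups, whereas this pair isolates a single atom, and the single-chloro ring also stays within the scatter of the 4-chloro-3-fluorophenyl group (a 1.3-fold lower number from compound 1 to compound 4 (0.10 log units; within the scatter)) and keeps the wide gap to the 4-isopropylphenyl group (an 8.7-fold lower number from compound 2 to compound 4 (0.94 log units; beyond the scatter)). No measurement shown here explains why the chloro can be lost without consequence.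

Still open, going by these compounds, is whether the remaining chloro is needed at all, which a plain phenyl group would test, and whether a fluoro, methoxy or nitrile group on the same carbon would give a similar number. Also open, on these data alone, is whether the high number of compound 2 comes with the isopropyl group itself or with where it sits on the ring, a question that a 3-isopropylphenyl group would help to separate.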